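Swapping Chloro for Fluoro at the Edge of Compound 1

The compounds below may be only part of what the source reports. "The series", "measured", "known", "first", "only" and "open" are said of these compounds alone.

Compound 1 `O=C(Nc1cc(-c2ccccn2)n[nH]1)N1CCC(c2ccc(Cl)cc2)CC1` is the starting point. Among the measured compounds shown here, in an ADME assay on liver (Mesocricetus auratus) for metabolic stability, using microsomes (on this read-out higher numbers stand for fast clearance and lower numbers for slow clearance), compound 1 gives 43.8 mL.min-1.g-1, and this is the only definite number among the three measured compounds. Compound 2 `COc1ccccc1C(=O)Nc1[nH]nc(-c2ccccn2)c1C1CC1` reaches only a limit of this assay, > 100 mL.min-1.g-1. Compound 3 `O=C(Nc1[nH]nc(-c2ccccn2)c1C1CC1)c1c(Cl)cccc1Cl` likewise gives only a limit, > 100 mL.min-1.g-1. For the measured compounds named here, the single step between measured compounds that differ in one place, a step that the two limits leave unreadable from compound 2 to compound 3, cannot be read because of the limit of > 100 mL.min-1.g-1 in this assay, at which 2 of the 3 values shown sit.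

Compound 4 `O=C(Nc1cc(-c2ccccn2)n[nH]1)N1CCC(c2ccc(F)cc2)CC1` differs from compound 1 by fluoro in place of chloro on an aromatic carbon. Going by the values given here, none of the measured steps concerns this exchange, and the two limits give no hint about a change of this kind, so the data offer no guide beyond compound 1 itself. The expectation is therefore no step beyond the usual scatter, a 1.1-fold lower number from compound 1 to compound 4 (0.04 log units; within the scatter). Compound 4 is expected to give about 40 mL.min-1.g-1 in this assay, with a likely range from 20 mL.min-1.g-1 to 85 mL.min-1.g-1.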

Compound 4, intrinsic clearance in microsomes: 272 mL.min-1.g-1
For compound 4 the middle estimate is 6.8-fold (0.83 log units) below the measured one, outside the stated range (above it).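

In this assay the change from 4-chlorophenyl to 4-fluorophenyl is not a silent one: one halogen exchanged for another on an aromatic carbon, para to a large group, gives a 6.2-fold higher number from compound 1 to compound 4 (0.79 log units; beyond the scatter) and moves the compound towards faster clearance. Among the compounds shown here, this is the first step that can be read, and it shows that this edge of compound 1 responds to which halogen it carries, even though both groups count as a single heavy atom with no ring and no charge. Nothing measured among the compounds shown accounts for the change.

Still open, going by these compounds, is how a nitrile, a trifluoromethyl group or a plain hydrogen would read at this place. Also open, on these data alone, is whether the same exchange behaves this way on any other core.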